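The source may hold more compounds than are shown below. What is called first, only, known or untested is meant among the compounds shown, and "the series" means these compounds.

In a functional assay on Gurav cells (Homo sapiens) for inhibition, read by sulforhodamine B assay (a higher number here means a weaker inhibitor of growth, a lower number a stronger inhibitor of growth), compound 1 (`Oc1cccc2[nH]c(-c3ccc(-c4ccc(-c5ccccc5)cc4)cc3)nc12`) gives 1110 nM, compound 2 (`Oc1cccc2[nH]c(-c3ccc(-c4ccc(-c5ccc(OC(F)(F)F)cc5)cc4)cc3)nc12`) gives 3600 nM and compound 3 (`COc1ccc(-c2ccc(-c3ccc(-c4nc5c(O)cccc5[nH]4)cc3)cc2)cc1`) gives 6630 nM. Compound 3 sits close to compound 2, with a 1.8-fold higher number from compound 2 to compound 3 (0.27 log units; within the scatter), and both numbers stand above that of compound 1. Compound 4 (`COc1ccc(-c2ccc(-c3ccc(-c4nc5c(O)cccc5[nH]4)cc3)cc2)cc1OC`) changes compound 3 by methoxy in place of hydrogen on an aromatic carbon, so that 4-methoxyphenyl becomes 3,4-dimethoxyphenyl. The closest measured steps are a 6.0-fold higher number from compound 1 to compound 3 (0.78 log units; beyond the scatter) and a 3.2-fold higher number from compound 1 to compound 2 (0.51 log units; beyond the scatter), both modest and both towards a higher number, though neither adds a second group to a ring already carrying one. A small further rise in this assay is therefore expected, and it may not clear the scatter. The expected change is a 1.4-fold higher number from compound 3 to compound 4 (0.13 log units; within the scatter). Compound 4 is estimated at 9000 nM, within a range of 3500 nM to 22000 nM.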

Compound 4, concentration for 50% growth inhibition: 1110 nM
The estimate for compound 4 lay 8.1-fold (0.91 log units) above the measured number, outside the stated range (below it).
By their numbers in this assay, from the lowest: compounds 1 and 4 (each within the scatter of the next); then compounds 2 and 3 (each within the scatter of the next).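

On the ring already carrying a methoxy group, a second methoxy lowers the number instead of raising it (a 6.0-fold lower number from compound 3 to compound 4 (0.78 log units; beyond the scatter)), the opposite direction to the earlier single substitutions on the terminal phenyl. The 3,4-dimethoxyphenyl group also gives a lower number than 4-(trifluoromethoxy)phenyl (a 3.2-fold lower number from compound 2 to compound 4 (0.51 log units; beyond the scatter)), and it fully offsets the earlier rise, with no change at the digits printed from compound 1 to compound 4 (within the scatter). No available evidence accounts for this reversal. Still open, going by these compounds, is whether a methoxy at this position gives the same number without the other methoxy group. An amine or a carboxylic acid here could also behave differently.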